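Replacing an Ester with a Thiazole: Expected Cytotoxicity

A few compounds are considered here, and "the series" means these few. Any claim that something is new, unique, unknown or untested is made for them only; others in the source may bear on it.

Three compounds sharing one core were tested in an ADME assay on PC-3 cells (Homo sapiens) for cytotoxicity, read by WST assay, tested at 100 uM; a lower number here means less inhibition, a higher number more inhibition at the concentration tested (going by the name of the read-out). Compound 1 `N#Cc1cccc(C(=O)N2CCCC(C(=O)Nc3ccc(Cl)cc3)C2)c1` gives 0%. Compound 2 `O=C(Nc1ccc(Cl)cc1)C1CCCN(C(=O)c2cccc(-c3cccs3)c2)C1` gives 4%. Compound 3 `COC(=O)c1cccc(C(=O)N2CCCC(C(=O)Nc3ccc(Cl)cc3)C2)c1` gives 0%, level with compound 1 and with it the lowest of the three; the widest gap, a number 4 percentage points lower from compound 2 to compound 3 (within the scatter), stays within the scatter, as do a number 4 percentage points higher from compound 1 to compound 2 (within the scatter) and no change at the digits printed from compound 1 to compound 3 (within the scatter). Compound 4 `Cc1nc(-c2cccc(C(=O)N3CCCC(C(=O)Nc4ccc(Cl)cc4)C3)c2)cs1` is not yet measured; it differs from compound 3 by 2-methyl-1,3-thiazol-4-yl in place of methoxycarbonyl on an aromatic carbon. The closest measured step, which also placed a five-membered aromatic ring on an aromatic carbon of the core, is a number 4 percentage points higher from compound 1 to compound 2 (within the scatter), and it stayed within the scatter. A step of a number 3 percentage points higher from compound 3 to compound 4 (within the scatter) is therefore expected, nothing beyond the scatter. Compound 4 is estimated at 3%, between 0% and 15%.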

Compound 4, a percentage reported as inhibition, at one concentration (the size of the read-out at that concentration, not a potency): 1%
Estimate against measurement, compound 4: 2 percentage points above; low and high end bracket the measured number.
By their numbers in this assay, from the lowest: compounds 1, 3, 4 and 2 (each within the scatter of the next).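

The steps of a number 1 percentage points higher from compound 3 to compound 4 (within the scatter) and a number 1 percentage points higher from compound 1 to compound 4 (within the scatter) and also a number 3 percentage points lower from compound 2 to compound 4 (within the scatter) show that in this assay a second five-membered aromatic ring at this position, here 2-methyl-1,3-thiazol-4-yl, reads no differently from the nitrile, the methoxycarbonyl or the thiophen-2-yl group. This place on the shared core has now held four different groups with every step inside the scatter. Going by these compounds, whether an amine or a carboxylic acid here would move the reading beyond the scatter remains open. No measurement is at hand that speaks to why these readings sit so close together.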